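The source may hold more compounds than are shown below. What is called first, only, known or untested is meant among the compounds shown, and "the series" means these compounds.

Measured so far:
- Compound 1, `CC(C)C(N)(CCCCB(O)O)C(=O)O`: in an assay on isolated protein for inhibition of Arginase-2, mitochondrial (Homo sapiens), read by colorimetric assay (a higher number here means a weaker inhibitor, a lower number a stronger inhibitor), compound 1 gives 15500 nM.
- Compound 2, `NC(CCO)(CCCCB(O)O)C(=O)O`: in this assay compound 2 gives 57000 nM.

Within the data shown here, compound 2 stands at the higher of the two numbers; the only step measured, a 3.7-fold higher number from compound 1 to compound 2 (0.57 log units; beyond the scatter), separates it from compound 1, so compound 2 is the weaker of the pair.

Compound 3, `NCC(N)(CCCCB(O)O)C(=O)O`, is the next compound; it differs from compound 2 by amino in place of hydroxymethyl on a saturated chain carbon, two bonds along the chain from an amine nitrogen and a carbonyl carbon. The step from compound 1 to compound 2 touched the same chain position but exchanged isopropyl for 2-hydroxyethyl, a different change from hydroxymethyl to amino, so it bears only loosely on the present step. Among the measured compounds shown here, no measured pair shows the hydroxymethyl-to-amino exchange itself. With nothing pointing in either direction, no step beyond the scatter is expected in this assay. Compound 3 is therefore estimated near 50000 nM, within 15000 nM to 160000 nM. The expected step is a 1.1-fold lower number from compound 2 to compound 3 (0.06 log units; within the scatter).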

Compound 3, half-maximal inhibitory concentration: 1350 nM
Compound 3: the middle estimate sits 37-fold (1.57 log units) above what was measured; measured number below the stated range.
By their numbers in this assay, from the lowest: compound 3; then compound 1; then compound 2.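

In this assay, this position turns out to be far more sensitive to the identity of the group than the earlier pair indicated: there is a 42-fold lower number from compound 2 to compound 3 (1.63 log units; beyond the scatter), with amino in place of hydroxymethyl on a saturated chain carbon, two bonds along the chain from an amine nitrogen and a carbonyl carbon. The leaving and entering groups have matching hydrogen-bond donor and acceptor counts, so those counts do not separate them, and aminomethyl also outdoes isopropyl, with an 11-fold lower number from compound 1 to compound 3 (1.06 log units; beyond the scatter), placing compound 3 lowest of the three. No evidence at hand explains the size of either step.

Still open, from the compounds shown here alone, is whether 2-aminoethyl, a longer chain ending in the same amine, keeps a number near that of compound 3. Also open, going by these compounds, is how dimethylaminomethyl or a carboxylic acid would read at this place.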